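Ethylamino in place of methyl on the shared core

A few compounds are considered here, and "the series" means these few. Any claim that something is new, unique, unknown or untested is made for them only; others in the source may bear on it.

Compound 1 `CNc1ncc(C#Cc2ccc(C)cc2)cn1` carries methylamino on the shared core; in an assay on HEK293 cells for positive allosteric modulation of metabotropic glutamate receptor 5 (Rattus norvegicus) (a higher number here means that more compound is needed for the effect, a lower number that less compound is needed), compound 1 gives 704000 nM, a very weak figure. Compound 2 `Cc1cccc(C#Cc2cnc(C)nc2)c1` carries methyl in that place; in this assay compound 2 gives "not active" (no number reported), so no number stands for it. Compound 3 `CCNc1ncc(C#Cc2cccc(C)c2)cn1` is still to be measured. From compound 2 to compound 3 the change is ethylamino in place of methyl on an aromatic carbon. For the measured compounds named here, no measured step covers this change; the only reference is compound 1 with its amino substituent at 704000 nM. Compound 3 is therefore expected to return a weak but measurable potency in this assay, estimated near 300000 nM with a range from 50000 nM to 2000000 nM.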

Compound 3, half-maximal effective concentration: "not active" (no number reported)
Nothing numeric was reported for compound 3; the estimate stays without a comparison.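

Compound 2 and compound 3 both lack a number in this assay so no step can be read between them. The compounds shown leave open whether ethylamino in place of methyl on the shared core changes potency. No supporting evidence bears on this result.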